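A few compounds are considered here, and "the series" means these few. Any claim that something is new, unique, unknown or untested is made for them only; others in the source may bear on it.

Measured in a functional assay on HL-60 cells (Homo sapiens) for inhibition, read by MTT assay, with a stated time of 72 h; on this read-out higher numbers stand for weaker inhibition and lower numbers for stronger inhibition:
- compound 1 `CC(=O)c1ccc(N2CCN(C(=O)c3oc(C)nc3-c3ccccc3)CC2)cc1`: "not active" (no number reported)
- compound 2 `Cc1ccc(N2CCN(C(=O)c3oc(C)nc3-c3ccccc3)CC2)c(C)c1`: 101 nM
- compound 3 `Cc1nc(-c2ccccc2)c(C(=O)N2CCN(c3ccc(C(F)(F)F)cc3)CC2)o1`: > 1000 nM (a limit)

Compound 3 has no single number, and its entry of > 1000 nM is only a limit. Compound 1 likewise gives no number. Compound 4 `Cc1nc(-c2ccccc2)c(C(=O)N2CCN(c3ccc(F)cc3)CC2)o1` has yet to be measured. It carries fluoro in place of trifluoromethyl on an aromatic carbon, para to a large group: fluoro in place of trifluoromethyl on an aromatic carbon.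

Going by the values given here, no measured step covers this exchange directly. The nearest is an at least 9.9-fold higher number from compound 2 to compound 3 (0.99 log units; beyond the scatter), in which 4-(trifluoromethyl)phenyl replaced 2,4-dimethylphenyl on an amine nitrogen in a ring. That step, beyond the scatter, shows that changing this aryl group alone can move the read-out substantially. Removing the trifluoromethyl group may therefore recover some inhibition, though a result without a number also remains possible.

The expected change is an at least 2.5-fold lower number from compound 3 to compound 4 (0.39 log units; beyond the scatter), towards a lower number. For compound 4 the estimated value is 400 nM, with an expected range from 100 nM to 1500 nM.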

Compound 4, half-maximal inhibitory concentration: > 1000 nM
Compound 4 was reported as a limit; the forecaster's own chance of this, stated with the estimate: 35%; middle value at least 2.5-fold (0.39 log units) away from the limit.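

In this assay compound 4 gives > 1000 nM, which is a limit and not a number. Even so, 4-fluorophenyl in place of 2,4-dimethylphenyl gives an at least 9.9-fold higher number from compound 2 to compound 4 (0.99 log units; beyond the scatter), so the smaller fluoro leaves the read-out as far from that of compound 2 as can be told, just as trifluoromethyl did. The exchange of trifluoromethyl for fluoro itself cannot be read, and the result stops at the same limit as compound 3: the limit of > 1000 nM in this assay, at which 2 of the 4 values shown sit.

Going by these compounds, how far compound 3 and compound 4 lie past that limit stays open, and with it any difference between fluoro and trifluoromethyl. Also open, on these data alone, is how a methoxy group or an amine would read in this assay on this aromatic carbon, para to a large group.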